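Sulfonamide benzoxazoles against a mitochondrial malate dehydrogenase

This account rests on a few compounds, and the source may have more. Where it says the series, first, only, none or still open, it means among the compounds named here.

Measured compounds:
compound 1, `O=S(=O)(Nc1ccc2oc(-c3ccccc3)nc2c1)c1ccccc1O`, > 63000 nM
compound 2, `O=S(=O)(Nc1ccc(-c2nc3ccccc3o2)cc1)c1ccccc1O`, > 63000 nM

In an assay on isolated protein for inhibition of malate dehydrogenase, mitochondrial (Sus scrofa), with stated times of 45 min and 30 min (a higher number here means a weaker inhibitor, a lower number a stronger inhibitor), compound 1 gives > 63000 nM, which is a limit of the assay rather than a number. In this assay compound 2 likewise gives > 63000 nM, again only a limit. Compound 2 therefore stands at the limit, and the limit of > 63000 nM in this assay, at which 2 of the 2 values shown sit, shows that both values shown sit there; nothing separates the two compounds on the numbers available.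

Compound 3, `O=S(=O)(Nc1ccc(-c2nc3ccccc3o2)cc1)c1cccc(F)c1`, is not yet measured. It differs from compound 2 in one place: 3-fluorophenyl in place of 2-hydroxyphenyl on a sulfonyl sulfur. Among the measured compounds shown here, no measured step is available to anchor this change, and both compounds known so far return only a limit. Compound 3 is expected to remain near that limit, with no step beyond the usual scatter, so the estimated step that the limit leaves unreadable from compound 2 to compound 3 is essentially flat. Compound 3 is accordingly estimated at 80000 nM, in a range from 15000 nM to 400000 nM, with a real chance that only a limit is reported again.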

Compound 3, half-maximal inhibitory concentration: > 63000 nM
Compound 3 was reported as a limit; the forecaster's own chance of this, stated with the estimate: 75%; the middle value does not contradict the limit.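

In this assay compound 3 gives > 63000 nM as a limit only. Among the compounds shown here, no step from compound 2 to compound 3 can be read: the limit of > 63000 nM in this assay, at which 3 of the 3 values shown sit.

The compounds shown leave open how strongly any of them inhibits the enzyme, and whether 3-fluorophenyl in place of 2-hydroxyphenyl changes that.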